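A few compounds are considered here, and "the series" means these few. Any claim that something is new, unique, unknown or untested is made for them only; others in the source may bear on it.

Measured in a functional assay on SGC-7901 cells (Homo sapiens) for antiproliferative activity, read by MTT assay, with a stated time of 72 h; a lower number here means a stronger inhibitor, a higher number a weaker inhibitor:
- compound 1 `COc1cc(-n2cnc3ccc(-c4ccc([N+](=O)[O-])cc4)cc32)cc(OC)c1OC`: 79 nM
- compound 2 `COc1cc(-n2cnc3ccc(-c4cccc(Cl)c4)cc32)cc(OC)c1OC`: 1490 nM

Compound 2 is the weaker of the two. Compound 3 `COc1cc(-n2cnc3ccc(-c4cccc(C)c4C)cc32)cc(OC)c1OC` has 2,3-dimethylphenyl in place of 3-chlorophenyl on an aromatic carbon. Among the measured compounds shown here, only one measured step bears on this place, and it is large: a 19-fold higher number from compound 1 to compound 2 (1.28 log units; beyond the scatter). For the measured compounds named here, that step shows the number can move widely here, but it involves 4-nitrophenyl, and no measured step involves 2,3-dimethylphenyl. In this assay, no step beyond the scatter is therefore expected, so the estimated step is a 1.2-fold lower number from compound 2 to compound 3 (0.09 log units; within the scatter). The range stays wide. For compound 3 the estimated value is 1200 nM, with an expected range of 300 nM to 5000 nM.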

Compound 3, half-maximal inhibitory concentration: 3040 nM
Compound 3: the middle estimate sits 2.5-fold (0.40 log units) below what was measured; measured number inside the range.
By their numbers in this assay, from the lowest: compound 1; then compound 2; then compound 3.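

In this assay, 2,3-dimethylphenyl in place of 3-chlorophenyl gives a 2.0-fold higher number from compound 2 to compound 3 (0.31 log units; beyond the scatter), so even a change between these two groups moves the number beyond the scatter. Against 4-nitrophenyl, the same group gives a 38-fold higher number from compound 1 to compound 3 (1.59 log units; beyond the scatter), and compound 1 remains clearly apart from the other two compounds. No evidence on the reason for these steps is available.

On these data alone, it remains open whether the low number of compound 1 depends on the nitro group itself. A phenyl ring carrying an amine or a carboxylic acid would test this.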